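Hydroxamic acids on a shared sulfonyl furoxan core

The source may report more compounds than this note shows. Statements on the series, on what has been measured and on what is new or still open speak of the compounds shown alone.

Measured so far in a functional assay on HCT-116 cells (Homo sapiens) for inhibition, read by MTT assay, with a stated time of 48 h; on this read-out lower numbers stand for stronger inhibition and higher numbers for weaker inhibition:
- compound 1, `O=C(CCCOc1no[n+]([O-])c1S(=O)(=O)c1ccccc1)NO`: 3830 nM
- compound 2, `O=C(CCCCOc1no[n+]([O-])c1S(=O)(=O)c1ccccc1)NO`: 2180 nM

Compound 2 stands at the lowest of the two numbers in this assay, but its nearest neighbour, compound 1, is only a 1.8-fold lower number from compound 1 to compound 2 (0.24 log units; within the scatter) away, so the two cannot be told apart on this read-out. Compound 3, `O=C(/C=C/COc1no[n+]([O-])c1S(=O)(=O)c1ccccc1)NO`, has not been measured. It differs from compound 2 by 2-(hydroxycarbamoyl)ethenyl in place of 3-(hydroxycarbamoyl)propyl on a saturated chain carbon bound to an oxygen on an aromatic ring. For the measured compounds named here, the only measured step that bears on this change is the one from compound 1 to compound 2, which lengthens the chain by one carbon and gives a 1.8-fold lower number from compound 1 to compound 2 (0.24 log units; within the scatter). Going by the values given here, compound 3 returns to the shorter chain of compound 1 while fixing a double bond into it; no measured pair speaks to that double bond. The expectation for compound 3 is therefore a number near those of compound 1 and compound 2, with a 1.4-fold higher number from compound 2 to compound 3 (0.14 log units; within the scatter) expected and no step beyond the scatter. Compound 3 is estimated at 3000 nM, within 1200 nM to 8000 nM.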

Compound 3, half-maximal inhibitory concentration: 59900 nM
Compound 3: middle estimate off by 20-fold (1.30 log units), on the low side; the measured number lies above the stated range.
By their numbers in this assay, from the lowest: compounds 2 and 1 (each within the scatter of the next); then compound 3.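

In this assay, for the compounds shown here, the chain on the saturated carbon bound to the aromatic oxygen had so far tolerated change, since adding one carbon moved the number only within the scatter (a 1.8-fold lower number from compound 1 to compound 2 (0.24 log units; within the scatter)). The result shows that this tolerance does not extend to a double bond: with 2-(hydroxycarbamoyl)ethenyl in place of 2-(hydroxycarbamoyl)ethyl, the comparison in which only the double bond is new, the step is large and beyond the scatter (a 16-fold higher number from compound 1 to compound 3 (1.19 log units; beyond the scatter)), and 2-(hydroxycarbamoyl)ethenyl in place of 3-(hydroxycarbamoyl)propyl gives a step of the same order (a 27-fold higher number from compound 2 to compound 3 (1.44 log units; beyond the scatter)). No measurement at hand accounts for this loss of inhibition on the cells.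

The compounds shown leave open whether the large step belongs to this double bond in this one arrangement, or whether the cis form of the chain or a carbon-carbon triple bond would give the same result. They also leave open whether a longer chain carrying the double bond, such as one reaching the hydroxamic acid through additional saturated carbons, would return the number to that of compound 2 (2180 nM).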